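This account rests on a few compounds, and the source may have more. Where it says the series, first, only, none or still open, it means among the compounds named here.

Measured in an ADME assay on a cell-free system (plasma, Mus musculus) for protein binding:
- compound 1 `CNc1nccc(N2CC[C@H](NC(=O)Nc3ccc(Cl)c(C(F)(F)F)c3)C2)n1` gives 99.8%
- compound 2 `CNc1nccc(N2CC[C@H](NC(=O)Nc3ccc(C)c(Cl)c3)C2)n1` gives 98.6%
- compound 3 `CCNc1nccc(N2CC[C@H](NC(=O)Nc3ccc(Cl)c(C(F)(F)F)c3)C2)n1` gives 99.9%

Compound 3, at 99.9%, lies within the scatter of compound 1, so these two cannot be ordered. Compound 2, at 98.6%, shows more free compound than compound 3, and that gap lies beyond the scatter.

The next structure is compound 4 `O=C(Nc1ccc(Cl)c(C(F)(F)F)c1)N[C@H]1CCN(c2ccnc(NC3CC3)n2)C1`. The change is cyclopropyl in place of ethyl on a nitrogen on an aromatic ring, in words cyclopropyl in place of ethyl on a nitrogen on an aromatic ring.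

Among the compounds with values here, only one measured step bears on this change: a 2.0-fold lower unbound fraction from compound 1 to compound 3 (0.30 log units; within the scatter). That step is methyl in place of hydrogen on a saturated chain carbon bound to a nitrogen on an aromatic ring, and it stays within the scatter. Within the data shown here, no measured compound carries the cyclopropyl group, so the support is indirect and rests on this single pair. Compound 2 differs from the others elsewhere in the structure and says nothing about this change.

No shift beyond the scatter is therefore expected in this assay, and the estimated change is a 1.5-fold higher unbound fraction from compound 3 to compound 4 (0.18 log units; within the scatter). For compound 4 the estimated value is 99.85%, with an expected range from 99.5% to 99.95%.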

Compound 4, plasma protein binding: 99.9%
For compound 4 the middle estimate is 1.5-fold (0.18 log units) (unbound fraction) above the measured one; low and high end bracket the measured number.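

Notes on the substituent on the nitrogen of the aromatic ring: in this assay, cyclopropyl in place of ethyl gives no change at the digits printed from compound 3 to compound 4 (within the scatter) and is the first ring at this position, adding one carbon to the ethyl group. Against the smaller methyl group, cyclopropyl gives a 2.0-fold lower unbound fraction from compound 1 to compound 4 (0.30 log units; within the scatter) and so also stays inside the usual variation, which means that methyl, ethyl and cyclopropyl cannot be ordered at this position when the rest of the structure is that of compound 1. No measurement on hand accounts for how closely these three groups read.

From the compounds shown here alone, whether a longer chain, a hydroxyethyl group, an aminoethyl chain or a carboxylic acid at this nitrogen would move the plasma protein binding beyond the usual variation remains open. Also open is whether cyclopropyl would read the same when the rest of the structure is that of compound 2, the only compound shown with a clearly larger free portion.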